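Furan-2-yl in Place of Cyclopropyl: What to Expect

The source may hold more compounds than are shown below. What is called first, only, known or untested is meant among the compounds shown, and "the series" means these compounds.

Measured compounds:
compound 1 `c1ccc(C(/N=C2\CCCCCCN2)C2CC2)cc1`, 58%
compound 2 `c1csc(C(/N=C2\CCCCCCN2)C2CC2)c1`, 50%

Among the measured compounds shown here, in a functional assay on the whole organism (plasma, strain Sprague-Dawley) with Rattus norvegicus as the target, with a stated time of 2 h, at a dose of 100 mg/kg by the oral route (a higher number here means a stronger effect of the compound at the dose given, a lower number a weaker effect), compound 1 gives 58%, the higher of the two numbers, but the only neighbour, compound 2, sits within the scatter of it: a number 8 percentage points lower from compound 1 to compound 2 (within the scatter). Compound 3 `c1ccc(C(/N=C2\CCCCCCN2)c2ccco2)cc1` differs from compound 1 in another place: furan-2-yl in place of cyclopropyl on a saturated chain carbon bound to an aromatic carbon and a double-bonded nitrogen. For the measured compounds named here, the one measured step concerns the phenyl position, not the cyclopropyl, so it bears on the new change only indirectly; it shows that exchanging one group on this carbon for a five-membered aromatic heterocycle left the result in this assay within the scatter. Going by the values given here, no measured step covers the cyclopropyl itself. Compound 3 is therefore expected to give about 52%, in a range from 30% to 75%. The expected step is a number 6 percentage points lower from compound 1 to compound 3 (within the scatter), not beyond the scatter in either direction.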

Compound 3, a percentage reported as inhibition, in the whole organism at one dose (the size of the read-out at that dose, not a potency): 61%
Compound 3: middle estimate off by 9 percentage points, on the low side; low and high end bracket the measured number.
By their numbers in this assay, from the lowest: compounds 2, 1 and 3 (each within the scatter of the next, the first and the last beyond it).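

Furan-2-yl in place of cyclopropyl gives a number 3 percentage points higher from compound 1 to compound 3 (within the scatter) in this assay. The earlier step concerned only the phenyl position, whereas this one shows that at the carbon bound to an aromatic carbon and a double-bonded nitrogen, a three-membered non-aromatic ring of carbon only can give way to a five-membered aromatic ring with 1 hetero atom and the read-out stays within the scatter. No independent measurement accompanies these compounds that would account for this result.

The compounds shown leave open how this position responds to a group of another kind, such as an amine, a carboxylic acid or a longer chain in place of the cyclopropyl. They also leave open whether the effect would be stronger or weaker at any other dose, as each number gives the size of the effect at one dose only.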